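The compounds below may be only part of what the source reports. "The series", "measured", "known", "first", "only" and "open" are said of these compounds alone.

Going by the values given here, in a physicochemical assay for lipophilicity (a lower number here means a more polar compound, a higher number a more lipophilic compound), compound 2 (`COCc1cc(-c2noc([C@H](C)NC(=O)c3cc(C(F)(F)F)nn3C)n2)ccn1`) gives 3, the lower of the two numbers so far, and compound 1 (`C[C@H](NC(=O)c1cc(C(F)(F)F)nn1C)c1nc(-c2ccnc(N3CCCC3)c2)no1`) gives 4.2. The change to compound 3 (`CNc1cc(-c2noc([C@H](C)NC(=O)c3cc(C(F)(F)F)nn3C)n2)ccn1`) is methylamino in place of methoxymethyl on an aromatic carbon, next to the ring nitrogen. Among the compounds with values here, the only measured step bearing on it is the large one, a number 1.20 log units lower from compound 1 to compound 2 (beyond the scatter), which involves methoxymethyl at the same place but pyrrolidin-1-yl rather than methylamino as its partner. No step beyond the scatter is expected in this assay, the estimate being a number 0.20 log units higher from compound 2 to compound 3 (within the scatter). For compound 3 the expected value is 3.2, with an estimated range from 2.8 to 3.6.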

Compound 3, distribution coefficient: 3.4
The estimate for compound 3 lay 0.20 log units below the measured number; measured number inside the range.
By their numbers in this assay, from the lowest: compound 2; then compound 3; then compound 1.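

In this assay this position on the pyridine ring separates even two small chains: methylamino in place of methoxymethyl gives a number 0.40 log units higher from compound 2 to compound 3 (beyond the scatter). Methylamino in place of pyrrolidin-1-yl gives a number 0.80 log units lower from compound 1 to compound 3 (beyond the scatter), so the methylamino compound lies between the other two and closer to the methoxymethyl one. No measurement shown accounts for either step. Open, on these data alone, is where an unsubstituted amino group, dimethylamino or ethylamino would fall at this place in this assay, and so whether the number tracks the size of the substituent on nitrogen.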